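Extending the ester chain on the acetoxymethyl analogue

The source may hold more compounds than are shown below. What is called first, only, known or untested is meant among the compounds shown, and "the series" means these compounds.

Compound 1 `Cc1nc2c(OCc3ccccc3)cccn2c1Cl` and compound 2 `CC(=O)OCc1c(C)nc2c(OCc3ccccc3)cccn12` share one core and differ only at one aromatic carbon. In a functional assay on the whole organism with Rattus norvegicus as the target, with a stated time of 4 h, at a dose of 40 mg/kg by the intraperitoneal route (on this read-out lower numbers stand for less inhibition and higher numbers for more inhibition at the one dose given (going by the name of the read-out)), compound 1 gives 93%, and compound 2 gives 88%. Going by the values given here, the step of a number 5 percentage points lower from compound 1 to compound 2 (within the scatter) lies within the scatter, so compound 2 cannot be set apart from compound 1; of the two numbers known, it is simply the second.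

Compound 3 `CCCCC(=O)OCc1c(C)nc2c(OCc3ccccc3)cccn12` carries the change (propyl in place of hydrogen on a saturated chain carbon bound to a carbonyl carbon). Among the compounds with values here, no measured step bears directly on this kind of change: the one known step, a number 5 percentage points lower from compound 1 to compound 2 (within the scatter), concerns acetoxymethyl in place of chloro, not the length of the chain bound to the carbonyl carbon. With nothing in the data pointing either way, the step of a number 3 percentage points lower from compound 2 to compound 3 (within the scatter) is expected to stay within the scatter, in no clear direction. For compound 3 the value in this assay is therefore estimated at 85%, with a range from 65% to 97%.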

Compound 3, a percentage reported as inhibition, in the whole organism at one dose (the size of the read-out at that dose, not a potency): 45%
Beside the measured number, compound 3's estimate is 40 percentage points above it; measured number outside the range, below it.
By their numbers in this assay, from the lowest: compound 3; then compounds 2 and 1 (each within the scatter of the next).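

This position is not indifferent to chain length: going from methyl to butyl on the ester gives a number 43 percentage points lower from compound 2 to compound 3 (beyond the scatter) in this assay, although the acetoxymethyl group had shown no change beyond the scatter from chloro. The ((butylcarbonyl)oxy)methyl group in place of chloro likewise gives a number 48 percentage points lower from compound 1 to compound 3 (beyond the scatter), so among these compounds an ester group as such does not set a compound apart from compound 1, while the butyl ester does. Nothing in the data shown bears on what lies behind this drop.

The compounds leave open whether the number falls gradually with chain length or abruptly, which an ethyl or propyl chain on the carbonyl carbon would show, and whether a longer chain such as hexyl lowers it further. They also leave open whether an amine or a carboxylic acid at the end of the chain would restore the number.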